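Adding a Methoxy Group to Compound 2

The source may report more compounds than this note shows. Statements on the series, on what has been measured and on what is new or still open speak of the compounds shown alone.

Compound 2 `COc1ccc(CNc2nc3cc(N)cc(N)c3nc2-c2ccccc2)cc1OC` shares its core with compound 1 `Nc1cc(N)c2nc(-c3ccccc3)c(NCc3ccc(Cl)c(Cl)c3)nc2c1`. In a functional assay on NCI-H23 cells (Homo sapiens) for inhibition, read by sulforhodamine B assay, with a stated time of 48 h (a lower number here means a stronger inhibitor of growth, a higher number a weaker inhibitor of growth), compound 1 gives 14100 nM, and compound 2 gives 17000 nM. For the measured compounds named here, the one step available, a 1.2-fold higher number from compound 1 to compound 2 (0.08 log units; within the scatter), exchanges 3,4-dichlorophenyl for 3,4-dimethoxyphenyl on a saturated chain carbon bound to a nitrogen on an aromatic ring. Among the two numbers shown, compound 2 stands nearest to compound 1, the two separated by a gap that lies within the scatter, so no order between them can be read.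

Compound 3 `COc1cc(CNc2nc3cc(N)cc(N)c3nc2-c2ccccc2)cc(OC)c1OC` is not yet measured. It differs from compound 2 by methoxy in place of hydrogen on an aromatic carbon of a six-membered aromatic ring of carbon only, ortho to a methoxy group, meta to a large group and meta to a methoxy group. Going by the values given here, only the step from compound 1 to compound 2 bears on this change, and it stayed within the scatter, so for this assay the expected step is one of no clear direction beyond the scatter, no change at the digits printed from compound 2 to compound 3 (within the scatter). Compound 3 is therefore estimated at 17000 nM, with an expected range from 7000 nM to 40000 nM.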

Compound 3, concentration for 50% growth inhibition: 8710 nM
For compound 3 the middle estimate is 2.0-fold (0.29 log units) above the measured one; low and high end bracket the measured number.
By their numbers in this assay, from the lowest: compounds 3, 1 and 2 (each within the scatter of the next).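

In this assay, methoxy in place of hydrogen on this aromatic carbon, ortho to a methoxy group and meta to a large group, gives a 2.0-fold lower number from compound 2 to compound 3 (0.29 log units; within the scatter). The earlier compounds had shown only an exchange of 3,4-dichlorophenyl for 3,4-dimethoxyphenyl, whereas this step isolates a single added methoxy group at one carbon, and that addition does not separate compound 3 from compound 2 beyond the scatter. Nothing in the material available explains the size of this step, and no measurement of any property of these compounds bears on it.

For the compounds shown here, since the only readable step at this carbon is from hydrogen to methoxy, it remains open whether a hydroxy group, an amine such as dimethylamino, a carboxylic acid or a longer chain such as ethoxy would give a step beyond the scatter in this assay. Also open, going by these compounds, is whether methoxy at this carbon would give a similar step without the neighbouring methoxy groups of compound 2, or on a ring bearing chlorine as in compound 1.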